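A few compounds are considered here, and "the series" means these few. Any claim that something is new, unique, unknown or untested is made for them only; others in the source may bear on it.

In a physicochemical assay for solubility, at pH 1.1 (on this read-out higher numbers stand for higher solubility and lower numbers for lower solubility), the three measured compounds give the same reading. Compound 1 `CCCN(Cc1ccc(OCCN2C(=O)CCC2=O)c(C)c1)[C@H](CC(=O)O)c1ccc(Cl)cc1` gives 3000000 nM. Compound 2 `CCN(Cc1ccc(OCCN2C(=O)CCC2=O)c(C)c1)C(CC(=O)O)c1ccc(Cl)cc1` gives 3000000 nM. Compound 3 `CCCCN(Cc1ccc(OCCN2C(=O)CCC2=O)c(C)c1)C(CC(=O)O)c1ccc(Cl)cc1` gives 3000000 nM, which places it level with the other two at the digits reported.

Compound 4 `Cc1cc(CN(CCC(F)(F)F)C(CC(=O)O)c2ccc(Cl)cc2)ccc1OCCN1C(=O)CCC1=O` has not yet been measured. It departs from compound 3 by a single change: trifluoromethyl in place of ethyl on a saturated chain carbon, two bonds along the chain from an amine nitrogen. This is trifluoromethyl in place of ethyl on a saturated chain carbon, two bonds along the chain from an amine nitrogen, and the same difference reads as butyl to 3,3,3-trifluoropropyl.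

Among the measured compounds shown here, only one measured step falls at this place: no change at the digits printed from compound 2 to compound 3 (within the scatter). For the measured compounds named here, it is indirect evidence, since it brings in ethyl in place of hydrogen and no measured compound carries fluorine. Resting on that single step, no change beyond the scatter is expected in this assay. The expected step is no change at the digits printed from compound 3 to compound 4 (within the scatter). Compound 4 is estimated at 3000000 nM, with an expected range of 1500000 nM to 3500000 nM.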

Compound 4, solubility: 3000000 nM
For compound 4 middle estimate and measured number coincide at the digits printed; measured number inside the range.
By their numbers in this assay, from the lowest: compounds 1, 2, 3 and 4 (each within the scatter of the next).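

In this assay, among the compounds shown here, the chain on the amine nitrogen now carries fluorine, which no earlier compound did, and trifluoromethyl in place of ethyl on this saturated chain carbon gives no change at the digits printed from compound 3 to compound 4 (within the scatter). Trifluoromethyl in place of hydrogen at the same place gives no change at the digits printed from compound 2 to compound 4 (within the scatter), so the reading holds across both hydrocarbon and fluorinated chain ends in these compounds. The data offer no explanation for this constant reading.

What the compounds shown leave open is whether a chain ending in a hydroxyl group, an amine or a nitrile, or a chain longer than butyl, would read the same in this assay. They also leave open whether a change elsewhere on the shared core, such as an ester in place of the carboxylic acid, would move the reading.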